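This account rests on a few compounds, and the source may have more. Where it says the series, first, only, none or still open, it means among the compounds named here.

Of the compounds shown here, three of one series have been measured in a functional assay on DU-145 cells (Homo sapiens) for cytotoxicity, read by sulforhodamine B assay, with a stated time of 48 h; on this read-out higher numbers stand for weaker inhibition of growth and lower numbers for stronger inhibition of growth. Compound 1 `CN1CCN(c2nc(Nc3ccc(C#N)c(C(F)(F)F)c3)nc(Oc3ccnc4ccccc34)n2)CC1` gives 51200 nM in this assay. For compound 2 `CC(C)N1CCN(c2nc(Nc3ccc(C#N)c(C(F)(F)F)c3)nc(Oc3ccnc4ccccc34)n2)CC1` this assay returns only a limit, > 100000 nM. Compound 3 `N#Cc1ccc(Nc2nc(Oc3ccnc4ccccc34)nc(N3CCN(c4ccccc4)CC3)n2)cc1C(F)(F)F` likewise yields only a limit, > 100000 nM, so its place on the numbers is known as a limit and nothing more; the limit of > 100000 nM in this assay, at which 2 of the 3 values shown sit, holds two of the three values. Compound 4 `N#Cc1ccc(Nc2nc(Oc3ccnc4ccccc34)nc(N3CCCCC3)n2)cc1C(F)(F)F` is not yet measured; the change is piperidin-1-yl in place of 4-phenylpiperazin-1-yl on an aromatic carbon. Going by the values given here, the steps that bear on it are an at least 1.9-fold higher number from compound 1 to compound 2 (0.29 log units; that floor lies within the scatter) and an at least 1.9-fold higher number from compound 1 to compound 3 (0.29 log units; that floor lies within the scatter), while a step that the two limits leave unreadable from compound 2 to compound 3. Among the compounds with values here, with only one numeric value and two limits, the size of the step cannot be read; the expected step is an at least 1.2-fold lower number from compound 3 to compound 4 (0.09 log units; that floor lies within the scatter). The estimate for compound 4 is 80000 nM, within 35000 nM to 200000 nM, with a fair chance that only a limit is reported again.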

Compound 4, concentration for 50% growth inhibition: 94900 nM
Compound 4: the middle estimate sits 1.2-fold (0.07 log units) below what was measured; measured number inside the range.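

With piperidin-1-yl at this position, this assay again returns a number rather than a limit, and the comparison with 4-methylpiperazin-1-yl reads a 1.9-fold higher number from compound 1 to compound 4 (0.27 log units; within the scatter). Against the other two groups the readings are an at least 1.0-fold lower number from compound 2 to compound 4 (0.02 log units; that floor lies within the scatter) and an at least 1.0-fold lower number from compound 3 to compound 4 (0.02 log units; that floor lies within the scatter), so no change here stands clear of the scatter. Removing the second ring nitrogen with its substituent is therefore not shown to matter in this assay.

The step between compound 2 and compound 3 cannot be read, and the top of the range stays unresolved: the limit of > 100000 nM in this assay, at which 2 of the 4 values shown sit. From the compounds shown here alone, whether a morpholine or a primary amine at this position would give a clearly lower number remains open.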